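The source may report more compounds than this note shows. Statements on the series, on what has been measured and on what is new or still open speak of the compounds shown alone.

Measured compounds:
Compound 1 `C#CCNc1nc(N)nc2c1ncn2[C@H]1C[C@H](N=[N+]=[N-])[C@@H](CO)O1` – a limit only: > 100000 nM.
Compound 2 `COc1nc(OC)c2ncn([C@H]3C[C@H](N=[N+]=[N-])[C@@H](CO)O3)c2n1` – a limit only: > 100000 nM.

In an ADME assay on CCRF-CEM cells (Homo sapiens) for cytotoxicity, with a stated time of 5 days (on this read-out higher numbers stand for weaker inhibition and lower numbers for stronger inhibition), compound 1 gives no number, only a limit, > 100000 nM. Compound 2 likewise gives only a limit in this assay, > 100000 nM. Both results sit at the same boundary of what the method reports (the limit of > 100000 nM in this assay, at which 2 of the 2 values shown sit), so compound 1 stands nowhere in particular among the numbers shown: neither compound has a measured value, and nothing separates them.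

Compound 3 `C=CCNc1nc(N)nc2c1ncn2[C@H]1C[C@H](N=[N+]=[N-])[C@@H](CO)O1` differs from compound 1 in one place: vinyl in place of ethynyl on a saturated chain carbon bound to a nitrogen on an aromatic ring. Among the measured compounds shown here, no step between two measured compounds is available, so there is no measured guide to what this change does. Given that both measured values sit at the boundary (the limit of > 100000 nM in this assay, at which 2 of the 2 values shown sit), the step that the limit leaves unreadable from compound 1 to compound 3 is expected to be none beyond the scatter. Compound 3 is therefore expected to return only a limit again, estimated at 150000 nM, with a range from 40000 nM to 600000 nM.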

Compound 3, half-maximal inhibitory concentration: > 100000 nM
Compound 3 gave a limit, no number (the forecaster's own chance of this, stated with the estimate: 85%); the middle value lies beyond the limit too.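

Compound 1 and compound 3 both return only a limit rather than a number, so the change from ethynyl to vinyl yields no readable step: the limit of > 100000 nM in this assay, at which 3 of the 3 values shown sit.

The compounds shown leave open what concentration, if any, would produce half-maximal inhibition in this assay, and whether this change affects it.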